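This account rests on a few compounds, and the source may have more. Where it says the series, first, only, none or still open, it means among the compounds named here.

Working notes on the series. In an ADME assay on microsomes from liver (Homo sapiens) for metabolic stability, read by LC-MS, using NADPH, with a stated time of 10 min, tested at 0.5 uM (on this read-out lower numbers stand for a less stable compound and higher numbers for a more stable compound), compound 1 `CC(=O)Nc1cc(-c2ccc(OC[C@@H](N)CC(C)C)c(F)c2)ccn1` gives 90%. Compound 2 `CC(=O)Nc1cc(-c2ccc(OC[C@@H](N)CC(C)C)c(C)c2)ccn1` gives 91%, and compound 3 `COC(=O)Nc1cc(-c2ccc(OC[C@@](C)(N)CC(C)C)c(Cl)n2)ccn1` gives 93%. Compound 2 therefore lies within the scatter of both other compounds, and the three numbers show no order among themselves.

The next comparison runs from compound 2 to compound 4 `CC(=O)Nc1cc(-c2ccc(OC[C@@H](N)CC(C)C)c(Cl)c2)ccn1`: chloro in place of methyl on an aromatic carbon. This is chloro in place of methyl on an aromatic carbon, ortho to a (2-amino-4-methylpentyl)oxy group.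

Within the data shown here, one measured step bears directly on this carbon: a number 1 percentage points higher from compound 1 to compound 2 (within the scatter), with methyl in place of fluoro, and this step lies within the scatter. Compound 3 also carries a chloro group, but it differs from compound 4 in more than one place, so compound 3 with 93% offers only general context. Among the measured compounds shown here, no measured step shows what chloro in place of methyl does on the core of compound 2.

On this limited evidence, no step beyond the scatter is expected in this assay. The expected change is no change at the digits printed from compound 2 to compound 4 (within the scatter). For compound 4 the estimated value is 91%, with an expected range of 84% to 97%.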

Compound 4, percent of the compound remaining: 89%
Estimate against measurement, compound 4: 2 percentage points above; low and high end bracket the measured number.
By their numbers in this assay, from the lowest: compounds 4, 1, 2 and 3 (each within the scatter of the next).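

In this assay the aromatic carbon ortho to a (2-amino-4-methylpentyl)oxy group can now be read with three groups on one core: chloro in place of methyl gives a number 2 percentage points lower from compound 2 to compound 4 (within the scatter), and chloro in place of fluoro gives a number 1 percentage points lower from compound 1 to compound 4 (within the scatter). Together with the earlier methyl and fluoro pair, this places chloro, methyl and fluoro on this carbon within the scatter of one another, so the series gives no order among the three groups at this position. Nothing at hand speaks to why these groups read alike here.

Open, from the compounds shown here alone, is whether this holds for groups of another kind on the same carbon, such as methoxy, a nitrile or an amine, or for a hydrogen there. Also open is whether chloro in place of methyl reads the same on a different core such as that of compound 3, for which no partner differing in one place is shown.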